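The source may report more compounds than this note shows. Statements on the series, on what has been measured and on what is new or still open speak of the compounds shown alone.

Measured in an ADME assay on HEK293 cells (Homo sapiens) for cytotoxicity, read by resazurin assay, with a stated time of 48 h; a lower number here means that less compound is tolerated, a higher number that more compound is tolerated:
Compound 1 `COc1ccc(S(=O)(=O)Nc2ccc3oc(-c4ccc(NC(=O)c5ccc(Cl)s5)cc4)nc3c2)cc1`: 15000 nM
Compound 2 `COc1c(Br)cccc1C(=O)Nc1ccc(Sc2nc3ccccc3s2)cc1`: > 100000 nM
Compound 3 `COc1c(Br)cccc1C(=O)Nc1ccc(Sc2nc3ccccc3s2)c(Cl)c1`: 40000 nM

Compound 2 gives > 100000 nM, which is a limit of this assay and not a number. It stands at the limit of > 100000 nM in this assay, at which 1 of the 3 values shown sits, so its true value is not known. Compound 1 differs from the others in more than one place, and its value of 15000 nM serves only as a sign of what numbers can appear here.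

The next compound is compound 4 `O=C(Nc1ccc(Sc2nc3ccccc3s2)cc1)c1cc(Br)cc(Br)c1O`. Its change from compound 2 is a group of 9 heavy atoms (6 carbon, 1 oxygen, 2 bromine; one six-membered aromatic ring of carbon only) in place of a group of 9 heavy atoms (7 carbon, 1 oxygen, 1 bromine; one six-membered aromatic ring of carbon only), on a carbonyl carbon. The group entering is 3,5-dibromo-2-hydroxyphenyl, attached on a carbonyl carbon.

For the measured compounds named here, only one measured step bears on this change: an at least 2.5-fold lower number from compound 2 to compound 3 (0.39 log units; beyond the scatter), a step beyond the scatter, with chloro in place of hydrogen on an aromatic carbon. Compound 4 also gains halogen, here as bromine, so a lower number is expected, on the strength of that step to compound 3 at 40000 nM. Going by the values given here, no measured step covers the whole group swap, so the expectation stays loose.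

The expected change is an at least 4.0-fold lower number from compound 2 to compound 4 (0.60 log units; beyond the scatter).

For compound 4 the estimate is 25000 nM, with an expected range of 6000 nM to 90000 nM.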

Compound 4, half-maximal cytotoxic concentration: 69000 nM
Compound 4: the middle estimate sits 2.8-fold (0.44 log units) below what was measured; measured number inside the range.
By their numbers in this assay, from the lowest: compound 1; then compounds 3 and 4 (each within the scatter of the next). At a limit, above all of these: compound 2.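

In this assay compound 4 gives 69000 nM, showing that with 3,5-dibromo-2-hydroxyphenyl on the carbonyl carbon the assay returns a measured number. For the compounds shown here, the earlier step concerned only chloro in place of hydrogen on an aromatic carbon, whereas this result is the first to test a swap of the whole group on the carbonyl carbon, and the step is an at least 1.4-fold lower number from compound 2 to compound 4 (0.16 log units; that floor lies within the scatter). Since that floor lies within the scatter, the result does not establish a real fall in the tolerated concentration, and the true size of the step stays unknown because compound 2 stands at a limit: the limit of > 100000 nM in this assay, at which 1 of the 4 values shown sits.

The compounds shown leave open whether the added bromine or the hydroxy group, with its hydrogen-bond donor, accounts for any change, a question that 3,5-dibromo-2-methoxyphenyl and 3-bromo-2-hydroxyphenyl on the same carbonyl carbon could help to separate. They also leave open how this assay would read with a ring on that carbonyl carbon carrying an amine or a carboxylic acid in place of the halogens.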